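Compound 3 to compound 4: the aryl group on sulfur

The source may hold more compounds than are shown below. What is called first, only, known or untested is meant among the compounds shown, and "the series" means these compounds.

In a functional assay on SMMC-7721 cells (Homo sapiens) for inhibition, read by CCK-8 assay, with a stated time of 72 h, tested at 2 uM (a lower number here means less inhibition of growth, a higher number more inhibition of growth at the concentration tested), compound 1 (`COc1ccc(SCc2ccc(/C=C/C(=O)Nc3ccccc3N)cc2)cc1OC`) gives 14.3% and compound 2 (`Nc1ccccc1NC(=O)/C=C/c1ccc(CSc2ccc(Cl)cc2)cc1`) gives 15.2% with no difference beyond the scatter. Compound 3 (`Nc1ccccc1NC(=O)/C=C/c1ccc(CSc2cccc3ccccc23)cc1`) stands lowest of the three at 3.7% in this assay and is the reference point here. The next structure is compound 4 (`CC(C)(C)c1ccc(SCc2ccc(/C=C/C(=O)Nc3ccccc3N)cc2)cc1`). The change is 4-(tert-butyl)phenyl in place of naphthalen-1-yl on a sulfur with 4-(tert-butyl)phenyl in place of naphthalen-1-yl on a sulfur. Going by the values given here, two measured steps bear on it: a number 10.6 percentage points lower from compound 1 to compound 3 (beyond the scatter) and a number 11.5 percentage points lower from compound 2 to compound 3 (beyond the scatter) are both modest and beyond the scatter, and both end at naphthalen-1-yl. The step of a number 0.9 percentage points higher from compound 1 to compound 2 (within the scatter) stays within the scatter, so 3,4-dimethoxyphenyl and 4-chlorophenyl do not separate. Read in reverse, these steps suggest a modest rise on leaving naphthalen-1-yl, although no 4-(tert-butyl)phenyl compound has yet been measured. The expected step is a number 9.3 percentage points higher from compound 3 to compound 4 (within the scatter) and would lie close to the edge of the scatter. Compound 4 is estimated at 13% within an expected range of 4% to 24% in this assay pending measurement.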

Compound 4, percent growth inhibition at one concentration: 18.3%
Compound 4: middle estimate off by 5.3 percentage points, on the low side, and the stated range covers the measured number.
By their numbers in this assay, from the lowest: compound 3; then compounds 1, 2 and 4 (each within the scatter of the next).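

In this assay, going by these compounds alone, the step of a number 14.6 percentage points higher from compound 3 to compound 4 (beyond the scatter) is the first to set a single-ring aryl group against naphthalen-1-yl at equal size, since both groups have 10 heavy atoms, so heavy-atom count does not account for the gap. The steps of a number 3.1 percentage points higher from compound 2 to compound 4 (within the scatter) and a number 4 percentage points higher from compound 1 to compound 4 (within the scatter) leave 4-(tert-butyl)phenyl unseparated from 4-chlorophenyl and 3,4-dimethoxyphenyl, so among the compounds shown, the three single-ring groups on this sulfur read alike and only naphthalen-1-yl stands apart, with no compound going against this. No measurement shown gives a reason for that gap.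

Open, as far as these compounds go, is how a non-aromatic group on the sulfur would read, such as cyclohexyl or a longer alkyl chain. Also open, from the compounds shown here alone, is whether an amine or a carboxylic acid on the phenyl ring would move the number clear of these three compounds.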